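The source may report more compounds than this note shows. Statements on the series, on what has been measured and on what is new or still open speak of the compounds shown alone.

Working notes on the shared core with two anilino groups and a hydrazone arm. Compound 1 `NS(=O)(=O)c1ccc(Nc2nc(N/N=C/c3ccc(C(F)(F)F)cc3)nc(Nc3ccccc3)n2)cc1` carries 4-(trifluoromethyl)phenyl on the carbon with a double bond to nitrogen; in a functional assay on IGROV-1 cells (Homo sapiens) for inhibition, read by sulforhodamine B assay, with a stated time of 48 h (on this read-out higher numbers stand for lower toxicity in this test and lower numbers for higher toxicity in this test), compound 1 gives 53800 nM. Compound 2 `Cc1nn(-c2ccccc2)cc1/C=N/Nc1nc(Nc2ccccc2)nc(Nc2ccc(S(N)(=O)=O)cc2)n1` carries 3-methyl-1-phenyl-1H-pyrazol-4-yl at that carbon. In this assay compound 2 reaches only a limit of the assay, > 100000 nM. The measured step is an at least 1.8-fold higher number from compound 1 to compound 2 (0.26 log units; that floor lies within the scatter). Compound 2 thus stands at the upper edge of the numbers shown and has no number of its own, since its value is the limit of > 100000 nM in this assay, at which 1 of the 2 values shown sits.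

Compound 3 `NS(=O)(=O)c1ccc(Nc2nc(N/N=C/c3ccccn3)nc(Nc3ccccc3)n2)cc1` differs from compound 2 in one place: pyridin-2-yl in place of 3-methyl-1-phenyl-1H-pyrazol-4-yl on a carbon with a double bond to nitrogen. Within the data shown here, no measured step covers this exchange. Among the measured compounds shown here, the only step on this carbon, from compound 1 to compound 2, stays within the scatter at its floor, so exchanges at this position have so far not moved the read-out beyond the scatter. The step expected for compound 3 is an at least 1.2-fold lower number from compound 2 to compound 3 (0.09 log units; that floor lies within the scatter), so compound 3 should remain near the limit. The estimate for compound 3 in this assay is 80000 nM, with a range from 30000 nM to 250000 nM, and a fair chance that only a limit is reported again.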

Compound 3, concentration lethal to 50% of the cells: > 100000 nM
Compound 3 ended at the assay's limit; the forecaster's own chance of this, stated with the estimate: 45%; middle value at least 1.2-fold (0.09 log units) away from the limit.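

In this assay compound 3 reaches a limit of the assay, > 100000 nM, and this is a limit, not a number. At the carbon with a double bond to nitrogen, pyridin-2-yl, with one six-membered aromatic ring with 1 hetero atom, now gives a second case alongside 3-methyl-1-phenyl-1H-pyrazol-4-yl, and the step is an at least 1.8-fold higher number from compound 1 to compound 3 (0.26 log units; that floor lies within the scatter), while the step between the two limits cannot be read. A second exchange away from 4-(trifluoromethyl)phenyl therefore also stays within the scatter at its floor, and the read-out at this position now clusters at one edge of the assay's range: the limit of > 100000 nM in this assay, at which 2 of the 3 values shown sit.

From the compounds shown here alone, how far compound 2 and compound 3 actually lie from compound 1 stays open, and so does any order between compound 2 and compound 3. Equally open, going by these compounds, is how a carboxylic acid, an amine or a longer alkyl chain on this carbon would read in this assay, and whether any group here gives a step beyond the scatter.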